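The source may hold more compounds than are shown below. What is called first, only, known or untested is meant among the compounds shown, and "the series" means these compounds.

Measured compounds:
compound 1, `Cc1cc(NC(=O)Nc2ccc(C(C)(C)C)cc2)c2ccccc2n1`, 20000 nM
compound 2, `Cc1cc(NC(=O)Nc2ccc(C(=O)O)c(O)c2)c2ccccc2n1`, > 25000 nM

Both were tested in an ADME assay on BJ cells (Homo sapiens) for cytotoxicity, with a stated time of 72 h; on this read-out lower numbers stand for an effect already at smaller amounts and higher numbers for an effect only at larger amounts of compound. Compound 1 gives 20000 nM, and this is the only number shown in this assay. Compound 2 gives > 25000 nM, which is a limit of the assay and not a number. the limit of > 25000 nM in this assay, at which 1 of the 2 values shown sits, is where that limit sits. Compound 1 therefore stands alone as a measured point: there is no second number to set beside it, and no change between measured compounds from which to learn how this read-out moves.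

Compound 3, `COc1ccc(NC(=O)Nc2cc(C)nc3ccccc23)cc1`, has not yet been measured. It differs from compound 1 in a single place: methoxy in place of tert-butyl on an aromatic carbon. The rest of the molecule is unchanged.

Among the measured compounds shown here, with no measured step to draw on, the expectation rests on compound 1 alone. The step from compound 1 to compound 3 in this assay is expected to be a 1.1-fold higher number from compound 1 to compound 3 (0.04 log units; within the scatter), a shift not expected to go beyond the usual scatter. Compound 3 is accordingly estimated at 22000 nM, with a range from 8000 nM to 50000 nM, and a real chance that the assay reports only its limit.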

Compound 3, half-maximal effective concentration: > 25000 nM
Compound 3: a limit, no number; the forecaster's own chance of this, stated with the estimate: 45%; middle value at least 1.1-fold (0.05 log units) away from the limit.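

In this assay, putting methoxy in place of tert-butyl on the aromatic carbon gives an at least 1.2-fold higher number from compound 1 to compound 3 (0.09 log units; that floor lies within the scatter). Compound 3 gives > 25000 nM, which is a limit of the assay and not a number. Among the compounds shown here, this is the first step that can be read at this position, but only its lower bound is known, and because that bound lies within the scatter, the change may be no real change at all; the read-out also offers little room to separate compounds at this end of its range: the limit of > 25000 nM in this assay, at which 2 of the 3 values shown sit.

Going by these compounds, the true size of the step remains open, as does whether any group at this position can bring the cytotoxic effect down to clearly smaller amounts of compound than compound 1 needs. An amine, a chlorine atom or a longer carbon chain on the same aromatic carbon could show whether this position matters for the read-out, provided such a compound gives a number and not a limit.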